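The source may hold more compounds than are shown below. What is called first, only, known or untested is meant among the compounds shown, and "the series" means these compounds.

Three ureas have been measured in an ADME assay on the whole organism with Oryza sativa as the target, tested at 0.1 uM; on this read-out lower numbers stand for a stronger effect and higher numbers for a weaker effect at the one concentration tested. Compound 1 `CCc1cccc(NC(=O)N[C@H](C)c2ccccc2)c1` gives 97%, compound 2 `CCc1cccc(NC(=O)N[C@@H](C)c2ccccc2)c1` gives 100%, and compound 3 `C[C@@H](NC(=O)Nc1ccccc1C(C)(C)C)c1ccccc1` gives 100%. Compound 1 sits at the low end of these three numbers, yet no one of them stands apart from the others beyond the scatter, so the three are read as one level. Among the compounds with values here, the only step between compounds differing in a single place is a number 3 percentage points higher from compound 1 to compound 2 (within the scatter), and that it stays within the scatter fits with the fact that compounds 1 and 2 differ only in the configuration as drawn.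

Compound 4 `C[C@@H](NC(=O)Nc1cccc(Cl)c1)c1ccccc1` has not yet been measured. It differs from compound 1 as follows: chloro in place of ethyl on an aromatic carbon. Within the data shown here, none of the measured steps changes a substituent on the aromatic ring in this way, so there is no measured step that bears directly on this change; the one step available, between compound 1 and compound 2, concerns configuration alone and was within the scatter. With the three measured numbers lying so close together, the expected step of no change at the digits printed from compound 1 to compound 4 (within the scatter) is none beyond the scatter. Compound 4 is therefore estimated at 97%, expected to fall between 85% and 100%.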

Compound 4, a percentage reported as activity, at one concentration (the size of the read-out at that concentration, not a potency): 97%
Compound 4: middle estimate and measured number agree at the digits printed, and the stated range covers the measured number.
By their numbers in this assay, from the lowest: compounds 1, 4, 2 and 3 (each within the scatter of the next).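

With chloro in place of ethyl on an aromatic carbon, meta to a large group, this assay shows no change at the digits printed from compound 1 to compound 4 (within the scatter) and so gives the same level as before. Within the data shown here, until now the only step between compounds differing in one place concerned configuration, so this is the one step that shows a change of substituent on the aromatic ring, and at this position ethyl and chloro cannot be told apart on this read-out. No information given here bears on why the two substituents read alike.

As far as these compounds go, what remains open is whether any group at this position moves the number beyond the scatter. An amine or a carboxylic acid on the same aromatic carbon, or a longer chain there, would be the next groups to read against compound 1 and compound 4.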